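The source may hold more compounds than are shown below. What is called first, only, known or untested is meant among the compounds shown, and "the series" means these compounds.

Compound 1, `FC(F)(F)c1ccc(Nc2cc3[nH]c(-c4cccc(C(F)(F)F)c4)nc3cn2)nc1`, was tested in a physicochemical assay for solubility, using the shake flask method, in simulated intestinal fluid, measured as kinetic solubility, with a stated time of 20 h, at pH 6.5; a lower number here means a less soluble compound, a higher number a more soluble compound. In this assay compound 1 gives >= 50000 nM, which is a limit of the assay rather than a measured number (the limit of >= 50000 nM in this assay, at which 1 of the 2 values shown sits). Compound 2, `FC(F)(F)c1cccc(-c2nc3cnc(Nc4ccc(-c5nnn[nH]5)cn4)cc3[nH]2)c1`, differs from compound 1 at one place; in this assay compound 2 gives < 5000 nM, again a limit (the limit of < 5000 nM in this assay, at which 1 of the 2 values shown sits). The change from compound 1 to compound 2 brought an at least 10-fold lower number from compound 1 to compound 2 (1.00 log units; beyond the scatter). Compound 3, `FC1(F)CCC(c2nc3cnc(Nc4ccc(C(F)(F)F)cn4)cc3[nH]2)CC1`, changes compound 1 at a different place: 4,4-difluorocyclohexyl in place of 3-(trifluoromethyl)phenyl on an aromatic carbon. For the measured compounds named here, no measured step covers this change, so the step from compound 1 to compound 2 does not bear on it directly, and the expectation rests on the limit seen for compound 1 alone. Compound 3 is therefore expected to sit near that limit, with an estimated step that the limit leaves unreadable from compound 1 to compound 3. The estimate for compound 3 is 60000 nM, within a range from 20000 nM to 200000 nM.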

Compound 3, solubility: 93000 nM
For compound 3 the middle estimate is 1.6-fold (0.19 log units) below the measured one, within the range that was stated.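

In this assay compound 1 gives >= 50000 nM, which is a limit and not a number. The step to compound 3 therefore cannot be read. The compounds shown leave open whether 4,4-difluorocyclohexyl in place of 3-(trifluoromethyl)phenyl changes this read-out at all, and by how much.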